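Replacing the Iodophenyl Group: Expected Potency of Compound 4

This account rests on a few compounds, and the source may have more. Where it says the series, first, only, none or still open, it means among the compounds named here.

Measured compounds:
- compound 1 `COC(=O)C1=C(C)N=C(C)/C(=C(\O)OC)C1c1ccc(I)cc1`: 22900 nM
- compound 2 `COC(=O)C1=C(C)N=C(C)/C(=C(\O)OC)C1c1ccccc1C`: 6.03 nM
- compound 3 `COC(=O)C1=C(C)N=C(C)/C(=C(\O)OC)C1c1cccc(O)c1`: 1000 nM

In a functional assay (muscle tissue) with Cavia porcellus as the target (on this read-out lower numbers stand for an effect already at smaller amounts and higher numbers for an effect only at larger amounts of compound), compound 1 gives 22900 nM, the highest of the three numbers. Its nearest neighbour is compound 3, with a 23-fold lower number from compound 1 to compound 3 (1.36 log units; beyond the scatter); its furthest is compound 2, with a 3800-fold lower number from compound 1 to compound 2 (3.58 log units; beyond the scatter). Between the two substituted analogues the gap is large as well, with a 170-fold higher number from compound 2 to compound 3 (2.22 log units; beyond the scatter).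

Compound 4 `COC(=O)C1=C(C)N=C(C)/C(=C(\O)OC)C1c1ccccc1F` has not yet been measured. It differs from compound 1 as follows: 2-fluorophenyl in place of 4-iodophenyl on a saturated ring carbon.

Going by the values given here, two measured steps bear on this change. Both replacements of the 4-iodophenyl group, by 2-methylphenyl and by 3-hydroxyphenyl, lowered the number, and the 2-methylphenyl replacement did so by far the more. Compound 4 carries a 2-fluorophenyl group, which shares with compound 2 a single substituent on the phenyl ring at the position named in its group name. A large drop in this assay is therefore expected from compound 1 to compound 4, of roughly the kind seen in the step to compound 2, though the number of compound 4 is expected with some caution, since fluorine and methyl have not been compared on this core.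

Compound 4 is estimated at 15 nM, within 3 nM to 100 nM, which is expected to correspond to a 1500-fold lower number from compound 1 to compound 4 (3.18 log units; beyond the scatter).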

Compound 4, half-maximal effective concentration: 42.7 nM
Beside the measured number, compound 4's estimate is 2.8-fold (0.45 log units) below it, within the range that was stated.
By their numbers in this assay, from the lowest: compound 2; then compound 4; then compound 3; then compound 1.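

In this assay, the 2-fluorophenyl group gives a 540-fold lower number from compound 1 to compound 4 (2.73 log units; beyond the scatter), so the large drop on leaving the 4-iodophenyl group is not confined to the 2-methylphenyl group of compound 2. The substituent on that ring still counts, however: fluoro in place of methyl gives a 7.1-fold higher number from compound 2 to compound 4 (0.85 log units; beyond the scatter), a modest step but one beyond the scatter, so the two 2-substituted phenyl groups are not interchangeable on the shared core. The step of a 23-fold lower number from compound 3 to compound 4 (1.37 log units; beyond the scatter) adds that the 2-fluorophenyl group also gives a much lower number than the 3-hydroxyphenyl group, though nothing at hand bears on the reason for any of these differences.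

Each of the four compounds carries a different substituent at a different place on the phenyl ring or a different group at the same place, so the contribution of the substituent's place cannot be separated from that of its identity across the iodo, hydroxy and fluoro compounds. From the compounds shown here alone, how a 4-fluorophenyl, a 2-iodophenyl or a 2-methoxyphenyl group would stand in this assay remains open, and these groups would bear directly on that question.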